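This account rests on a few compounds, and the source may have more. Where it says the series, first, only, none or still open, it means among the compounds named here.

Three compounds have been measured in a functional assay on BGC-823 cells (Homo sapiens) for antiproliferative activity, read by MTT assay, with a stated time of 24 h; a higher number here means a weaker inhibitor, a lower number a stronger inhibitor:
Compound 1, `c1ccc(CSc2nnc(-c3ccc4c(c3)OCCO4)n2-c2ccccc2)cc1`, gives 73400 nM.
Compound 2, `Fc1ccc(CSc2nnc(-c3ccc4c(c3)OCCO4)n2-c2ccccc2)c(F)c1`, returns > 100000 nM, which is a limit of the assay and not a number.
Compound 3, `Fc1cccc(F)c1CSc1nnc(-c2ccc3c(c2)OCCO3)n1-c1ccccc1`, gives 84200 nM.

Of the two numbers, compound 1 carries the lower one, but its nearest neighbour is compound 3 and the step of a 1.1-fold higher number from compound 1 to compound 3 (0.06 log units; within the scatter) lies within the scatter, so the two are not separated. Compound 2 sits at the limit described by the limit of > 100000 nM in this assay, at which 1 of the 3 values shown sits, and the step of an at least 1.3-fold higher number from compound 1 to compound 2 (0.13 log units; that floor lies within the scatter) has a floor that also lies within the scatter.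

Compound 4, `Brc1ccccc1CSc1nnc(-c2ccc3c(c2)OCCO3)n1-c1ccccc1`, differs from compound 1 by bromo in place of hydrogen on an aromatic carbon. The measured steps that bear on it are those that also decorate the benzyl ring: a 1.1-fold higher number from compound 1 to compound 3 (0.06 log units; within the scatter), where fluorine occupies the same kind of position, and an at least 1.3-fold higher number from compound 1 to compound 2 (0.13 log units; that floor lies within the scatter). Neither moved this assay beyond its scatter, and neither gives a direction that can be trusted.

On that basis compound 4 is expected to show a 1.1-fold higher number from compound 1 to compound 4 (0.04 log units; within the scatter), that is, no step beyond the scatter. The estimate for compound 4 in this assay is 80000 nM, with a range from 40000 nM to 160000 nM.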

Compound 4, half-maximal inhibitory concentration: > 100000 nM
Compound 4: only a limit was reported; the forecaster's own chance of this, stated with the estimate: 30%; middle value at least 1.2-fold (0.09 log units) away from the limit.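

Bromo in place of hydrogen on this aromatic carbon, ortho to a large group, gives an at least 1.3-fold higher number from compound 1 to compound 4 (0.13 log units; that floor lies within the scatter), and as the result for compound 4 is a limit, the true size of that step stays unknown. Set against the 2,6-difluorophenyl group, the 2-bromophenyl group gives an at least 1.1-fold higher number from compound 3 to compound 4 (0.07 log units; that floor lies within the scatter), while the step between compound 2 and compound 4 cannot be read. What compound 4 adds is that a single bromo, like the two fluorines of compound 2 and compound 3, gives no lower number than the unsubstituted benzyl of compound 1, and a second compound now stands at the limit: the limit of > 100000 nM in this assay, at which 2 of the 4 values shown sit.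

As far as these compounds go, how far compound 2 and compound 4 actually lie past that limit stays open, so it cannot be told whether bromo moves the number at all. Also open, from the compounds shown here alone, is whether an amine, a carboxylic acid or a methoxy group on this ring, or a longer chain in place of benzyl, would give a lower number in this assay.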